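Hydroxy to acetoxy in a weak growth inhibitor

A few compounds are considered here, and "the series" means these few. Any claim that something is new, unique, unknown or untested is made for them only; others in the source may bear on it.

Compound 1 `CC[C@@H]1O[C@H](COCc2ccccc2)[C@@H](OCc2ccccc2)[C@H](OCc2ccccc2)[C@H]1OC(C)=O`: > 50000 nM
Compound 2 `C=CC[C@@H]1O[C@H](COCc2ccccc2)[C@@H](OCc2ccccc2)[C@H](OCc2ccccc2)[C@H]1O`: 44100 nM

For the measured compounds named here, in a functional assay on HOS cells (Homo sapiens) for antiproliferative activity, read by sulforhodamine B assay (on this read-out higher numbers stand for weaker inhibition of growth and lower numbers for stronger inhibition of growth), compound 2 gives 44100 nM, the only actual number so far. Compound 1, which carries acetoxy, reports only a limit of > 50000 nM. Compound 3 `C=CC[C@@H]1O[C@H](COCc2ccccc2)[C@@H](OCc2ccccc2)[C@H](OCc2ccccc2)[C@H]1OC(C)=O` differs from compound 2 by acetyl in place of hydrogen on an oxygen on a saturated carbon, with acetyl in place of hydrogen on an oxygen on a saturated carbon. Going by the values given here, no measured pair shows this change alone, so in this assay only a small step is expected, with no clear direction beyond the scatter. The expected step of a 1.1-fold lower number from compound 2 to compound 3 (0.04 log units; within the scatter) is an estimate. The estimated value for compound 3 is 40000 nM, with an expected range of 17000 nM to 50000 nM.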

Compound 3, concentration for 50% growth inhibition: 11000 nM
Compound 3: the middle estimate sits 3.6-fold (0.56 log units) above what was measured, and the stated range ends above it.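

Acetyl in place of hydrogen on an oxygen on a saturated carbon gives a 4.0-fold lower number from compound 2 to compound 3 (0.60 log units; beyond the scatter) in this assay, the first pair shown in which this change stands alone. With acetoxy held constant, vinyl in place of methyl on a saturated chain carbon bound to a saturated ring carbon gives an at least 4.5-fold lower number from compound 1 to compound 3 (0.65 log units; beyond the scatter). That second step starts from a limit for compound 1, not from a number: the limit of > 50000 nM in this assay, at which 1 of the 3 values shown sits.

The compounds shown leave open whether an amine or a longer ester, such as benzoyloxy, in place of acetoxy would follow the same direction. They also do not tell why acetyl lowers the number.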